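The source may report more compounds than this note shows. Statements on the series, on what has been measured and on what is new or still open speak of the compounds shown alone.

Measured so far:
compound 1 `CC(O)(C[S+]([O-])c1ccc(F)cc1F)C(=O)Nc1ccc([N+](=O)[O-])cc1C(F)(F)F` — 51100 nM
compound 2 `CC(O)(C[S+]([O-])c1ccc(F)c(F)c1)C(=O)Nc1ccc([N+](=O)[O-])cc1C(F)(F)F` — > 100000 nM; > 100000 nM (2 entries)

For the measured compounds named here, in a functional assay on CWR22R cells (Homo sapiens) for antiproliferative activity (on this read-out higher numbers stand for weaker inhibition and lower numbers for stronger inhibition), compound 1 gives 51100 nM, the only plain number in the set. For compound 2 the read-out is a limit of the assay, > 100000 nM; > 100000 nM (2 entries), and not a number. Compound 3 `CC(O)(C[S+]([O-])c1ccc(OC(F)(F)F)cc1)C(=O)Nc1ccc([N+](=O)[O-])cc1C(F)(F)F` differs from compound 1 in one place: 4-(trifluoromethoxy)phenyl in place of 2,4-difluorophenyl on a sulfur. Going by the values given here, no step between measured compounds is available, so there is no precedent for the size of this change; the expected step is a 1.1-fold lower number from compound 1 to compound 3 (0.06 log units; within the scatter), none beyond the scatter in either direction. Compound 3 is estimated at 45000 nM, with a range from 12000 nM to 160000 nM, and a limit read-out remains a real possibility.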

Compound 3, half-maximal inhibitory concentration: > 100000 nM
Compound 3 was reported as a limit; the forecaster's own chance of this, stated with the estimate: 35%; middle value at least 2.2-fold (0.34 log units) from the limit.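

In this assay, 4-(trifluoromethoxy)phenyl in place of 2,4-difluorophenyl on the sulfur gives an at least 1.9-fold higher number from compound 1 to compound 3 (0.29 log units; that floor lies within the scatter). The read-out for compound 3 is a limit of the assay and not a number, so the step is only a floor: the limit of > 100000 nM in this assay, at which 1 of the 3 values shown sits. For the compounds shown here, the larger group on this sulfur therefore brings no gain over the 2,4-difluorophenyl of compound 1, which remains the only compound here with a plain number.

From the compounds shown here alone, how far compound 3 truly lies from compound 1 stays open. Also open, going by these compounds, is whether an amine or a carboxylic acid on this aromatic ring would give a lower number.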